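Swapping the Heteroaryl Group on a Sulfonamide Nitrogen

A few compounds are considered here, and "the series" means these few. Any claim that something is new, unique, unknown or untested is made for them only; others in the source may bear on it.

Measured compounds:
- compound 1, `O=S(=O)(Nc1nccs1)c1ccc(-c2nnc(Cc3ccc(Cl)c(Cl)c3)[nH]2)cc1`, 45 nM
- compound 2, `O=C(NCc1ccc(OC(F)(F)F)c(Cl)c1)c1ccc(S(=O)(=O)Nc2ncc(F)cn2)c(F)c1`, 993 nM

In an assay on cells for inhibition of sodium channel protein type 3 subunit alpha (Homo sapiens), read by electrophysiology (on this read-out lower numbers stand for stronger inhibition and higher numbers for weaker inhibition), compound 1 gives 45 nM and compound 2 gives 993 nM, so compound 2 has the higher of the two numbers, and the gap to compound 1 lies beyond the scatter of repeated measurements. The two compounds differ in many places at once, so nothing can be said about any single structural cause of that gap.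

Compound 3, `O=C(NCc1ccc(OC(F)(F)F)c(Cl)c1)c1ccc(S(=O)(=O)Nc2cccnn2)c(F)c1`, has not yet been measured. It differs from compound 2 in one place only: pyridazin-3-yl in place of 5-fluoropyrimidin-2-yl on a sulfonamide nitrogen. One six-membered aromatic ring with two hetero atoms is replaced by another, the fluorine is lost, and the rest of the molecule is kept. Going by the values given here, no measured pair here shows the effect of such a swap, so the expectation rests on the single change alone. The step from compound 2 to compound 3 is expected to be small, a 1.2-fold higher number from compound 2 to compound 3 (0.08 log units; within the scatter), with no clear direction beyond the scatter. Compound 3 is therefore estimated at 1200 nM, with a range from 400 nM to 3600 nM.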

Compound 3, half-maximal inhibitory concentration: 1790 nM
Compound 3: the middle estimate sits 1.5-fold (0.17 log units) below what was measured, and the stated range covers the measured number.
By their numbers in this assay, from the lowest: compound 1; then compounds 2 and 3 (each within the scatter of the next).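

In this assay, putting pyridazin-3-yl in place of 5-fluoropyrimidin-2-yl on a sulfonamide nitrogen gives a 1.8-fold higher number from compound 2 to compound 3 (0.26 log units; within the scatter), so this measurement does not tell the two groups apart. This is the first comparison shown that isolates a single change at this position, and it suggests that this particular ring swap, on this core, is tolerated without a clear shift in the read-out. The fluorine and the original ring leave together, so this one pair cannot separate their contributions, and no measurement here offers an explanation for the result.

Still open, as far as these compounds go, is what a plain methyl group or a longer alkyl chain on the same sulfonamide nitrogen would do. Also open, from the compounds shown here alone, is how the ring carried on that nitrogen in compound 1 would behave on the core of compound 2.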